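A methyl on the chain, tried a second time

The source may hold more compounds than are shown below. What is called first, only, known or untested is meant among the compounds shown, and "the series" means these compounds.

Compound 1, `CC1=C(N2CC2)C(=O)C(C(C)COC(N)=O)=C(N2CC2)C1=O`: 6.41
Compound 2, `CCC1=C(N2CC2)C(=O)C(CCOC(N)=O)=C(N2CC2)C1=O`: 6.25
Compound 3, `CCC(COC(N)=O)C1=C(N2CC2)C(=O)C(C)=C(N2CC2)C1=O`: 6.18

Of the compounds shown here, three have been measured in a functional assay on L1210 cells (Mus musculus), with a stated time of 12 days; a higher number here means a more potent compound, by a factor of ten per unit of this negative logarithm, a lower number a less potent compound. Compound 1 and compound 3 differ in one place, (methyl in place of hydrogen on a saturated chain carbon, two bonds along the chain from a double-bonded ring carbon), and the measured step is a number 0.23 log units lower from compound 1 to compound 3 (within the scatter). Compound 2 has the same atoms as compound 1 joined differently; the difference between the two cores is not broken down here. Compound 2 stands within the scatter of both compound 1 and compound 3, so no order among the three can be read from these numbers.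

Compound 4, `CCCC1=C(N2CC2)C(=O)C(CCOC(N)=O)=C(N2CC2)C1=O`, has not yet been measured in this assay. It differs from compound 2 by methyl in place of hydrogen on a saturated chain carbon, two bonds along the chain from a double-bonded ring carbon, the same change, at the same place, as that from compound 1 to compound 3. Among the compounds with values here, the expected step is a number 0.20 log units lower from compound 2 to compound 4 (within the scatter), resting on the one measured precedent, because a number 0.23 log units lower from compound 1 to compound 3 (within the scatter) was within the scatter. Compound 4 is therefore expected to give 6.05, most likely between 5.7 and 6.4.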

Compound 4, logarithm of the reciprocal of the active concentration, log(1/C): 5.68
Estimate against measurement, compound 4: 0.37 log units above; the whole stated range lies above it.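

In this assay, methyl in place of hydrogen on a saturated chain carbon, two bonds along the chain from a double-bonded ring carbon, here read as ethyl to propyl, gives a number 0.57 log units lower from compound 2 to compound 4 (beyond the scatter). Set beside the earlier step on the other core, this one cannot be told apart from it, so as far as these two pairs go, the change carries from one core to the other with a step of similar size: the same change on two cores in this assay, a number 0.23 log units lower (within the scatter) from compound 1 to compound 3 and a number 0.57 log units lower (beyond the scatter) from compound 2 to compound 4, 0.34 log units apart, within the scatter of two such steps This does not show that the step is fixed, since only the later step lies beyond the scatter, and two pairs say nothing about a third core.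

The compounds shown leave open whether a longer chain, such as butyl, in place of the propyl of compound 4 would continue the step. They also leave open whether the same change would carry over if the carbamate at the end of the other chain gave way to an amine or a carboxylic acid.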